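The source may hold more compounds than are shown below. What is called first, only, known or untested is meant among the compounds shown, and "the series" means these compounds.

Measured so far in a functional assay on A549 cells (Homo sapiens) for cytotoxicity, read by MTT assay, with a stated time of 72 h; on this read-out higher numbers stand for weaker inhibition and lower numbers for stronger inhibition: compound 1 `COc1ccc(Nc2nc3ccccc3nc2S(=O)(=O)c2ccccc2)cc1` gives 11900 nM. Compound 2 `COc1ccc(Nc2nc3ccccc3nc2S(=O)(=O)c2ccc(C)cc2)cc1` reaches only a limit of measurement, > 50000 nM. Compound 3 `COc1ccc(Nc2nc3ccccc3nc2S(=O)(=O)c2ccc(Br)cc2)cc1` gives 3340 nM.

Compound 3 therefore holds the lowest of the two numbers; its nearest neighbour is compound 1, separated by a 3.6-fold lower number from compound 1 to compound 3 (0.55 log units; beyond the scatter). Compound 4 `O=S(=O)(c1ccc(Br)cc1)c1nc2ccccc2nc1Nc1cccc(O)c1` differs from compound 3 in 3-hydroxyphenyl in place of 4-methoxyphenyl on a nitrogen on an aromatic ring. Every measured step alters the other aromatic ring instead: an at least 4.2-fold higher number from compound 1 to compound 2 (0.62 log units; beyond the scatter), a 3.6-fold lower number from compound 1 to compound 3 (0.55 log units; beyond the scatter) and an at least 14-fold lower number from compound 2 to compound 3 (1.17 log units; beyond the scatter). None bears directly on the new change, so the step in this assay is expected to stay near the scatter. For compound 4 the estimate is 5000 nM, within 1500 nM to 20000 nM. Compound 4 is thus expected to show a 1.5-fold higher number from compound 3 to compound 4 (0.18 log units; within the scatter).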

Compound 4, half-maximal inhibitory concentration: 8000 nM
Beside the measured number, compound 4's estimate is 1.6-fold (0.20 log units) below it; low and high end bracket the measured number.
By their numbers in this assay, from the lowest: compound 3; then compounds 4 and 1 (each within the scatter of the next). At a limit, above all of these: compound 2.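

Going by these compounds alone, the only measured change on the nitrogen side of the shared core, 3-hydroxyphenyl in place of 4-methoxyphenyl, gives in this assay a 2.4-fold higher number from compound 3 to compound 4 (0.38 log units; beyond the scatter). This position therefore responds to substitution, though modestly, and with the bromo group held constant. Nothing shown here accounts for this step.

The change replaces the methoxy group with a hydroxy group and also moves the substituent on the ring, so the two contributions remain unseparated. On these data alone, how an amine or a carboxylic acid on this ring would read also remains open.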